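Adding a single fluorine to the phenyl of compound 3

The compounds below may be only part of what the source reports. "The series", "measured", "known", "first", "only" and "open" are said of these compounds alone.

Compound 3 `CC1CCN(c2c(S(=O)(=O)c3ccccc3)cnc3ccc(Cl)cc23)CC1` gives 59% in an assay on isolated protein for displacement of a labelled ligand from metabotropic glutamate receptor 5 (Homo sapiens), with a stated time of 60 min, tested at 1 uM (a higher number here means more inhibition at the concentration tested (going by the name of the read-out), a lower number less inhibition), the lowest of the three values measured. Compound 1 `CC1CCN(c2c(S(=O)(=O)c3cccc(C#N)c3)cnc3ccc(Cl)cc23)CC1` gives 90% and compound 2 `CC1CCN(c2c(S(=O)(=O)c3cc(F)cc(F)c3)cnc3ccc(Cl)cc23)CC1` gives 93%, while the steps of a number 31 percentage points lower from compound 1 to compound 3 (beyond the scatter) and a number 34 percentage points lower from compound 2 to compound 3 (beyond the scatter) were both large. Compound 4 `CC1CCN(c2c(S(=O)(=O)c3ccc(F)cc3)cnc3ccc(Cl)cc23)CC1` carries the change (fluoro in place of hydrogen on an aromatic carbon). The step from compound 2 to compound 3, which removed two fluorines, bears most directly on this move; the step from compound 1 to compound 3 points the same way. Compound 4 is therefore expected to recover part of that loss, with an estimated a number 16 percentage points higher from compound 3 to compound 4 (beyond the scatter). In this assay compound 4 is expected to give about 75%, within 55% to 93%.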

Compound 4, a percentage reported as inhibition, at one concentration (the size of the read-out at that concentration, not a potency): 89%
The estimate for compound 4 lay 14 percentage points below the measured number, within the range that was stated.
By their numbers in this assay, from the lowest: compound 3; then compounds 4, 1 and 2 (each within the scatter of the next).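

In this assay, one fluoro para to a large group is enough to give a number 30 percentage points higher from compound 3 to compound 4 (beyond the scatter), so the full effect on the phenyl does not depend on a second fluorine. The 4-fluorophenyl also stands level with the other aryl groups on the sulfonyl sulfur, with a number 4 percentage points lower from compound 2 to compound 4 (within the scatter) and a number 1 percentage points lower from compound 1 to compound 4 (within the scatter). No evidence on hand accounts for this gain. Open, as far as these compounds go, is whether a chloro, a methoxy or an amine at this same position would match the fluoro, and whether one fluoro elsewhere on the phenyl would do the same.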